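This account rests on a few compounds, and the source may have more. Where it says the series, first, only, none or still open, it means among the compounds named here.

Working notes on the series in a functional assay on HepG2 cells (Homo sapiens) for cytotoxicity, read by MTT assay, with a stated time of 24 h; a higher number here means a weaker inhibitor, a lower number a stronger inhibitor. Compound 1 (`O=C1/C(=C/c2cccnc2)CNC/C1=C\c1ccccc1C(F)(F)F`) gives 5020 nM, and compound 2 (`Cc1ccc(S(=O)(=O)N2C/C(=C\c3cccnc3)C(=O)/C(=C/c3ccccc3C(F)(F)F)C2)cc1`), which carries (4-methylphenyl)sulfonyl in place of hydrogen on the ring amine nitrogen, gives 2930 nM. Within the data shown here, these two values cannot be ranked, so compound 2 stands level with the only other measured member of the series.

Compound 3 (`O=C1/C(=C/c2cccnc2)CN(S(=O)(=O)c2ccc(C(F)(F)F)cc2)C/C1=C\c1ccccc1C(F)(F)F`) is the next to be read. It differs from compound 2 by trifluoromethyl in place of methyl on an aromatic carbon, turning 4-methylphenyl into 4-(trifluoromethyl)phenyl. Among the measured compounds shown here, no measured step covers this exact exchange. The nearest evidence is a 1.7-fold lower number from compound 1 to compound 2 (0.23 log units; within the scatter), which introduced the whole sulfonyl group and stayed within the scatter. On that single step, the smaller exchange within the group is expected to produce no shift beyond the scatter, and no direction is favoured. The expected change is a 1.1-fold lower number from compound 2 to compound 3 (0.04 log units; within the scatter). For compound 3 the estimated value is 2700 nM, with an expected range from 1100 nM to 6500 nM.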

Compound 3, half-maximal inhibitory concentration: 1710 nM
Estimate against measurement, compound 3: 1.6-fold (0.20 log units) above; the measured number falls inside the stated range.
By their numbers in this assay, from the lowest: compounds 3, 2 and 1 (each within the scatter of the next, the first and the last beyond it).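

In this assay, the sulfonyl aryl ring now has a reading of its own: trifluoromethyl in place of methyl, on the aromatic carbon para to a large group, gives a 1.7-fold lower number from compound 2 to compound 3 (0.23 log units; within the scatter) and so does not separate the two compounds, despite four heavy atoms entering where one left. Taken one step at a time, the series shows no separation, yet compound 1 at 5020 nM and compound 3 at 1710 nM lie beyond the scatter of each other, so the unsubstituted ring amine and the 4-(trifluoromethyl)phenyl sulfonyl compound can be ranked where neighbouring members cannot. No measurement shown here accounts for either the step or this wider gap.

Still open, on these data alone, is whether this aromatic carbon accepts a group of a different kind, such as an amine, a carboxylic acid or a methoxy group, with a larger change than the one seen here. Also open, as far as these compounds go, is whether the sulfonyl link itself matters, which an acetyl group or a plain benzyl group on the ring nitrogen would begin to address.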